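Methylating the Phenol: From Compound 2 to Compound 3

The source may report more compounds than this note shows. Statements on the series, on what has been measured and on what is new or still open speak of the compounds shown alone.

Compound 1 `O=C(Nc1cccc(-n2cc(-c3ccncc3)c(-c3cc(O)cc(Cl)c3)n2)c1)Nc1ccc(Cl)c(C(F)(F)F)c1`: -33.6%
Compound 2 `O=C(Nc1cccc(-n2cc(-c3ccncc3)c(-c3cc(O)cc(Cl)c3)n2)c1)Nc1ccc(Cl)c(Cl)c1`: -33.8%

In a functional assay on SW-620 cells (Homo sapiens) for inhibition, read by sulforhodamine B assay, with a stated time of 48 h, tested at 10 uM (a higher number here means a weaker effect of the compound at the concentration tested, a lower number a stronger effect), compound 2 gives -33.8%, the lowest of the two numbers shown, while compound 1 gives -33.6%; the step of a number 0.2 percentage points lower from compound 1 to compound 2 (within the scatter) lies within the scatter. Compound 3 `COc1cc(Cl)cc(-c2nn(-c3cccc(NC(=O)Nc4ccc(Cl)c(Cl)c4)c3)cc2-c2ccncc2)c1` differs from compound 2 by methyl in place of hydrogen on an oxygen on an aromatic ring. Going by the values given here, the only measured step, a number 0.2 percentage points lower from compound 1 to compound 2 (within the scatter), changes another group and was within the scatter, so no measured step bears directly on this change. For compound 3 the expected step of a number 5.8 percentage points higher from compound 2 to compound 3 (within the scatter) is therefore none beyond the scatter, and its estimated value is -28%, within -50% to 0%.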

Compound 3, a percentage reported as activity, at one concentration (the size of the read-out at that concentration, not a potency): 13.3%
Compound 3: the middle estimate sits 41.3 percentage points below what was measured; the whole stated range lies below it.
By their numbers in this assay, from the lowest: compounds 2 and 1 (each within the scatter of the next); then compound 3.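

In this assay, going from hydroxy to methoxy on the 3-chloro-5-hydroxyphenyl group gives a number 47.1 percentage points higher from compound 2 to compound 3 (beyond the scatter), a large loss of effect at the concentration tested. So this oxygen is sensitive to adding a single methyl, whereas the only earlier change, elsewhere in the molecule, stayed within the scatter. Nothing available explains this loss. On these data alone, it remains open whether a free hydroxy is specifically needed, or whether an amine or a longer ethoxy chain at this place would behave like hydroxy or like methoxy.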